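Hydrazine substituent change within the shared core series

The compounds below may be only part of what the source reports. "The series", "measured", "known", "first", "only" and "open" are said of these compounds alone.

For the measured compounds named here, the shared core carries a methylphenyl group and a substituted hydrazine on its remaining position; compound 1 `Cc1ccccc1-c1nnc(N(C)N)s1` and compound 2 `Cc1ccccc1-c1nnc(NNC2CCCC2)s1` are the two measured members. In a functional assay on the whole organism with Mus musculus as the target, in the maximal electroshock model, with a stated time of 1 h (on this read-out higher numbers stand for an effect only at larger amounts of compound and lower numbers for an effect already at smaller amounts), compound 1 gives 75 mg/kg. For compound 2 the result in this assay is only a limit of the assay, > 100 mg/kg. Compound 2 thus stands at the limit of > 100 mg/kg in this assay, at which 1 of the 2 values shown sits. No number fixes where compound 2 lies against compound 1. Compound 3 `Cc1ccccc1-c1nnc(NN(C)C)s1` differs from compound 2 by dimethylamino in place of cyclopentylamino on a nitrogen on an aromatic ring. Going by the values given here, no step between measured compounds covers this change. For compound 3 the expected step is an at least 1.1-fold lower number from compound 2 to compound 3 (0.04 log units; that floor lies within the scatter), a move toward smaller doses that may not exceed the scatter. Compound 3 is therefore estimated at 90 mg/kg in this assay, with a range from 45 mg/kg to 200 mg/kg.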

Compound 3, dose for half-maximal effect: 60 mg/kg
The estimate for compound 3 lay 1.5-fold (0.18 log units) above the measured number, within the range that was stated.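

Dimethylamino in place of cyclopentylamino on a nitrogen on an aromatic ring turns a limit into a measured number in this assay, with the step reading an at least 1.6-fold lower number from compound 2 to compound 3 (0.22 log units; that floor lies within the scatter) on this read-out. That step is only a floor, and its true size stays unfixed, so the change to the smaller, ring-free group cannot yet be sized: the limit of > 100 mg/kg in this assay, at which 1 of the 3 values shown sits. The change of (dimethylamino)amino in place of amino(methyl)amino on an aromatic carbon gives a 1.3-fold lower number from compound 1 to compound 3 (0.10 log units; within the scatter) in this series, so the two substituted hydrazines are not told apart here.

As far as these compounds go, how diethylamino or a piperidine ring on the same nitrogen would read remains open, which leaves the effect of size and ring on this nitrogen unresolved. Also open, from the compounds shown here alone, is how the series responds when the methylphenyl group gives way to a chlorophenyl group.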